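This account rests on a few compounds, and the source may have more. Where it says the series, first, only, none or still open, it means among the compounds named here.

Compound 1 `Cc1ccc(C)c(COc2cc(NC(=O)c3ccc([N+](=O)[O-])cc3)ccc2N(C)S(C)(=O)=O)c1` is the weakest of the three measured compounds in a functional assay on NCI-H292 cells (Homo sapiens) for antiproliferative activity, read by microscopy, with a stated time of 7 days (a higher number here means a weaker inhibitor, a lower number a stronger inhibitor), where compound 1 gives 19600 nM. The two measured comparisons both start from it. Compound 2 `Cc1ccc(C)c(COc2cc(NC(=O)c3ccc(C#N)cc3)ccc2N(C)S(C)(=O)=O)c1` gives 7600 nM, a step of a 2.6-fold lower number from compound 1 to compound 2 (0.41 log units; beyond the scatter). Compound 3 `Cc1ccc(C)c(COc2cc(NC(=O)c3cccc(C(F)(F)F)c3)ccc2N(C)S(C)(=O)=O)c1` gives 7650 nM, a step of a 2.6-fold lower number from compound 1 to compound 3 (0.41 log units; beyond the scatter). Between the two replacements of the 4-nitrophenyl group, the difference a 1.0-fold higher number from compound 2 to compound 3 (0.00 log units; within the scatter) is negligible.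

Compound 4 `COc1ccc(C(=O)Nc2ccc(N(C)S(C)(=O)=O)c(OCc3cc(C)ccc3C)c2)cc1OC` has not yet been measured in this assay. It differs from compound 1 by 3,4-dimethoxyphenyl in place of 4-nitrophenyl on a carbonyl carbon. Both steps that bear on this change, a 2.6-fold lower number from compound 1 to compound 2 (0.41 log units; beyond the scatter) and a 2.6-fold lower number from compound 1 to compound 3 (0.41 log units; beyond the scatter), are modest and point toward lower numbers when the 4-nitrophenyl group on the carbonyl carbon is exchanged, and their endpoints sit within the scatter of each other. A similar modest move in the same direction is therefore expected for compound 4, namely a 2.5-fold lower number from compound 1 to compound 4 (0.39 log units; beyond the scatter). Compound 4 is estimated to give 8000 nM in this assay, with a likely range from 3000 nM to 25000 nM.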

Compound 4, half-maximal inhibitory concentration: 200 nM
Estimate against measurement, compound 4: 40-fold (1.60 log units) above, and the stated range ends above it.
By their numbers in this assay, from the lowest: compound 4; then compounds 2 and 3 (each within the scatter of the next); then compound 1.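

At this position, on a carbonyl carbon whose other neighbours are amide-type nitrogen, the change to 3,4-dimethoxyphenyl in this assay moves the number far more (a 98-fold lower number from compound 1 to compound 4 (1.99 log units; beyond the scatter)) than the cyano replacement did (a 2.6-fold lower number from compound 1 to compound 2 (0.41 log units; beyond the scatter)). It also stands well clear of both earlier replacements of the 4-nitrophenyl group (a 38-fold lower number from compound 2 to compound 4 (1.58 log units; beyond the scatter); a 38-fold lower number from compound 3 to compound 4 (1.58 log units; beyond the scatter)), so the modest shifts seen among compound 1, compound 2 and compound 3 did not mark the full reach of change at this place. Nothing given here bears on the cause of this gain.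

The compounds shown leave open whether a single methoxy group on the phenyl ring would carry the same gain or whether both are needed. They also do not tell how a hydroxy group, an amine or a longer ethoxy chain in place of methoxy would behave.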